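This account rests on a few compounds, and the source may have more. Where it says the series, first, only, none or still open, it means among the compounds named here.

Measured so far in a functional assay on PANC-1 cells (Homo sapiens) for antiproliferative activity, read by MTT assay, with a stated time of 48 h; a lower number here means a stronger inhibitor, a higher number a weaker inhibitor:
- compound 1 `COc1ccc(-c2c(Nc3ccc(F)cc3)c3ccccc3oc2=O)cc1`: 32000 nM
- compound 2 `COc1ccc(-c2c(Nc3ccc(C)c(O)c3)c3ccccc3oc2=O)cc1`: 9750 nM
- compound 3 `COc1ccc2oc(=O)c(C(=O)C(F)(F)F)c(Nc3ccc(F)cc3)c2c1`: "not determined" (no result reported)

Compound 1 and compound 2 share a core and differ only in the group on the nitrogen, (3-hydroxy-4-methylphenyl in place of 4-fluorophenyl on a nitrogen on an aromatic ring). That single exchange gives a 3.3-fold lower number from compound 1 to compound 2 (0.52 log units; beyond the scatter), a modest gain that lies beyond the scatter.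

Compound 3 carries a different core; how it differs from compound 1 is not broken down here. Compound 4 `COc1ccc2oc(=O)c(C(=O)C(F)(F)F)c(Nc3ccc(C)c(O)c3)c2c1` is to be measured in this assay and stands to compound 3 exactly as compound 2 stands to compound 1: 3-hydroxy-4-methylphenyl in place of 4-fluorophenyl on a nitrogen on an aromatic ring. The place is the same in both pairs, a nitrogen on an aromatic ring whose other neighbour is an aromatic carbon, so the change is the same one, seen twice among these compounds.

Within the data shown here, compound 3 gives no number, so no measured step can be set beside the earlier one, and the estimate for compound 4 rests only on compound 2 and on the size of the earlier step. Compound 4 is expected to land near 10000 nM in this assay, within a broad range from 2000 nM to 50000 nM, the width reflecting that the core of compound 4 has no measured anchor.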

Compound 4, half-maximal inhibitory concentration: 5620 nM
Compound 4: the middle estimate sits 1.8-fold (0.25 log units) above what was measured; measured number inside the range.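

In this assay, among these compounds, compound 3 has no reported number, so no step from compound 3 to compound 4 can be read. The compounds shown leave open whether the exchange of 4-fluorophenyl for 3-hydroxy-4-methylphenyl on the core of compound 3 matches a 3.3-fold lower number from compound 1 to compound 2 (0.52 log units; beyond the scatter) or differs from it. Nothing available here bears on the result.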